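Swapping a nitro for a hydroxy on the hydrazone aryl ring

The source may report more compounds than this note shows. Statements on the series, on what has been measured and on what is new or still open speak of the compounds shown alone.

Measured so far:
compound 1, `O=C(N/N=C/c1ccc([N+](=O)[O-])cc1)Nc1cc2c(Nc3ccc(F)c(Cl)c3)ncnc2cc1O[C@H]1CCOC1`: 33500 nM
compound 2, `O=C(N/N=C/c1cccc(Cl)c1Cl)Nc1cc2c(Nc3ccc(F)c(Cl)c3)ncnc2cc1O[C@H]1CCOC1`: 27400 nM

Both compounds share a large core and differ only in the aryl group hanging from the carbon that carries a double bond to nitrogen. In a functional assay on PC-3 cells (Homo sapiens) for cytotoxicity, read by MTT assay, with a stated time of 72 h (a lower number here means a stronger inhibitor, a higher number a weaker inhibitor), compound 1 gives 33500 nM, the highest of the two numbers, and compound 2 gives 27400 nM. The step between them, a 1.2-fold lower number from compound 1 to compound 2 (0.09 log units; within the scatter), shows that exchanging one aryl substitution pattern for another left the read-out essentially where it was.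

Compound 3, `O=C(N/N=C/c1ccc(O)cc1)Nc1cc2c(Nc3ccc(F)c(Cl)c3)ncnc2cc1O[C@H]1CCOC1`, has not yet been measured. It departs from compound 1 by hydroxy in place of nitro on an aromatic carbon. For the measured compounds named here, the one step that bears on this, a 1.2-fold lower number from compound 1 to compound 2 (0.09 log units; within the scatter), moved the number only within the scatter, so no step beyond the scatter is expected here either. The expected step is a 1.1-fold lower number from compound 1 to compound 3 (0.05 log units; within the scatter). Compound 3 is estimated at 30000 nM, between 12000 nM and 75000 nM.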

Compound 3, half-maximal inhibitory concentration: 4890 nM
For compound 3 the middle estimate is 6.1-fold (0.79 log units) above the measured one, outside the stated range (below it).
By their numbers in this assay, from the lowest: compound 3; then compounds 2 and 1 (each within the scatter of the next).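

In this assay, the substituent on this aromatic carbon, para to a large group, clearly matters: hydroxy in place of nitro brings a drop beyond the scatter (a 6.9-fold lower number from compound 1 to compound 3 (0.84 log units; beyond the scatter)), and 4-hydroxyphenyl in place of 2,3-dichlorophenyl brings a similar one (a 5.6-fold lower number from compound 2 to compound 3 (0.75 log units; beyond the scatter)). The earlier pair gave no hint of this, as its step stayed within the scatter (a 1.2-fold lower number from compound 1 to compound 2 (0.09 log units; within the scatter)), so the aryl group is not indifferent to the read-out, and compound 3 has the lowest number of the three. Nothing measured here bears on what lies behind this drop.

The compounds shown leave open whether the lower number belongs to hydroxy itself or would also appear with an amine, a methoxy group or a carboxylic acid on the same carbon. They also leave open whether hydroxy would give a similar step elsewhere on the ring.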